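The source may report more compounds than this note shows. Statements on the series, on what has been measured and on what is new or still open speak of the compounds shown alone.

Compound 1 `Fc1ccc(-c2cc(/C=N/c3ccccc3)on2)cc1` gives 33100 nM in a functional assay on COLO 205 cells (Homo sapiens) for inhibition, read by MTT assay, with a stated time of 24 h; a lower number here means a stronger inhibitor, a higher number a weaker inhibitor. Compound 2 `Cc1ccc(-c2cc(/C=N/c3ccccc3)on2)cc1` gives 28900 nM in this assay. Compound 3 `CCc1cc2ccccc2nc1-c1cc(-c2ccc(F)cc2)no1` gives in this assay only a limit, > 100000 nM, and that limit is the limit of > 100000 nM in this assay, at which 1 of the 3 values shown sits.

Compound 4 `CCc1cc2ccccc2nc1-c1cc(-c2ccc(C)cc2)no1` has not yet been measured in this assay. From compound 1 to compound 2 the change is methyl in place of fluoro on an aromatic carbon, and that step was a 1.1-fold lower number from compound 1 to compound 2 (0.06 log units; within the scatter). From compound 3 to compound 4 the change is methyl in place of fluoro on an aromatic carbon, the same change on the same kind of place. How the core of compound 1 and the core of compound 3 differ is not broken down here. Because compound 3 already sits at the limit of > 100000 nM in this assay, at which 1 of the 3 values shown sits, and the same change gave a 1.1-fold lower number from compound 1 to compound 2 (0.06 log units; within the scatter), the step is expected to be a step that the limit leaves unreadable from compound 3 to compound 4. Compound 4 is therefore estimated at 150000 nM, with a real chance that only a limit is reported again.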

Compound 4, half-maximal inhibitory concentration: > 100000 nM
Compound 4: a limit, no number; the forecaster's own chance of this, stated with the estimate: 70%; the middle value lies beyond the limit too.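

Compound 3 and compound 4 both give only a limit, and the step between them cannot be read. The compounds shown leave open whether methyl in place of fluoro changes anything on the core of compound 3.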